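Three amine side chains on one core, fourth awaited

The compounds below may be only part of what the source reports. "The series", "measured", "known", "first", "only" and "open" are said of these compounds alone.

Measured so far in an in vitro ADME assay on microsomes from liver (Homo sapiens) for pharmacokinetics; on this read-out higher numbers stand for fast clearance and lower numbers for slow clearance:
compound 1, `CN(CCN1CCCCC1)c1ccc(Cn2c(=O)[nH]c3c(N)nc(C(F)(F)F)cc32)cn1`: 25 mL.min-1.g-1
compound 2, `CN1CCN(CCN(C)c2ccc(Cn3c(=O)[nH]c4c(N)nc(C(F)(F)F)cc43)cn2)CC1`: 25 mL.min-1.g-1
compound 3, `CN1CCN(c2ccc(Cn3c(=O)[nH]c4c(N)nc(C(F)(F)F)cc43)cn2)CC1`: 30 mL.min-1.g-1

Compound 1 stands level with compound 2, the two together giving the lowest numbers of the three in this assay; its nearest neighbour is compound 2 with no change at the digits printed from compound 1 to compound 2 (within the scatter), and its furthest is compound 3 with a 1.2-fold higher number from compound 1 to compound 3 (0.08 log units; within the scatter). All three measured compounds thus sit within the scatter of one another.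

Compound 4, `CN(C)CCN1CCN(c2ccc(Cn3c(=O)[nH]c4c(N)nc(C(F)(F)F)cc43)cn2)CC1`, has not yet been measured. It differs from compound 1 as follows: 4-(2-(dimethylamino)ethyl)piperazin-1-yl in place of methyl(2-(piperidin-1-yl)ethyl)amino on an aromatic carbon

Within the data shown here, the steps that bear on this change are a 1.2-fold higher number from compound 1 to compound 3 (0.08 log units; within the scatter) and a 1.2-fold higher number from compound 2 to compound 3 (0.08 log units; within the scatter), both exchanges of a side chain on the same aromatic carbon, and no change at the digits printed from compound 1 to compound 2 (within the scatter), an exchange within the chain. None of them moved the number beyond the scatter. Compound 4 is therefore expected to give a step of a 1.1-fold higher number from compound 1 to compound 4 (0.05 log units; within the scatter) in this assay, that is, no change beyond the scatter. For compound 4 the estimated value is 28 mL.min-1.g-1, with a range from 15 mL.min-1.g-1 to 55 mL.min-1.g-1.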

Compound 4, intrinsic clearance in microsomes: < 8 mL.min-1.g-1
Compound 4 ended at the assay's limit; the forecaster's own chance of this, stated with the estimate: 5%; middle value at least 3.5-fold (0.54 log units) from the limit.
By their numbers in this assay, from the lowest: compounds 1, 2 and 3 (each within the scatter of the next). At a limit, below all of these: compound 4.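

In this assay, among these compounds, the side chains on this aromatic carbon, next to the ring nitrogen, had so far stayed within the scatter of one another, and 4-(2-(dimethylamino)ethyl)piperazin-1-yl is the first to move the number beyond it, with an at least 3.1-fold lower number from compound 1 to compound 4 (0.49 log units; beyond the scatter) and an at least 3.1-fold lower number from compound 2 to compound 4 (0.49 log units; beyond the scatter). The piperazine itself is common to compound 3 and compound 4, and extending the chain on it still gives an at least 3.7-fold lower number from compound 3 to compound 4 (0.57 log units; beyond the scatter), so the shift appears with the (dimethylamino)ethyl end and not with the ring alone. The value of compound 4 is a limit, not a number: the limit of < 8 mL.min-1.g-1 in this assay, at which 1 of the 4 values shown sits.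

The compounds shown cannot separate the terminal dimethylamino group from the ethyl chain carrying it; a hydroxyl group on that chain, a pyrrolidine in place of the dimethylamino group, or a longer chain would bear on this. On these data alone, the full size of these steps also stays open.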